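Aryl Group Restored on the Ring Nitrogen of Compound 2

A few compounds are considered here, and "the series" means these few. Any claim that something is new, unique, unknown or untested is made for them only; others in the source may bear on it.

Compound 1 `CC(=O)Oc1cccc(N2C(=O)/C(=C/N3N=C(c4ccccc4)CC3c3ccccc3O)SC2=S)c1` gives 118 nM in a functional assay on HL-60 cells (Homo sapiens) for antiproliferative activity, read by MTT assay, with a stated time of 72 h; a higher number here means a weaker inhibitor, a lower number a stronger inhibitor. Compound 2 `CCN1C(=O)/C(=C/N2N=C(c3ccccc3)CC2c2ccccc2O)SC1=S` reaches only a limit in this assay, > 10000 nM, so its standing among the numbers is a range rather than a point (the limit of > 10000 nM in this assay, at which 1 of the 2 values shown sits). Within the data shown here, the one measured step, an at least 84-fold higher number from compound 1 to compound 2 (1.92 log units; beyond the scatter), is large. Compound 3 `O=C1/C(=C/N2N=C(c3ccccc3)CC2c2ccccc2O)SC(=S)N1c1cccc(C(F)(F)F)c1` differs from compound 2 by 3-(trifluoromethyl)phenyl in place of ethyl on an amide-type nitrogen in a ring. The measured step bears on this change directly: it is the reverse move, an aryl group returning to that nitrogen, though as 3-(trifluoromethyl)phenyl rather than 3-acetoxyphenyl. On that basis a large step toward lower numbers in this assay is expected, an at least 50-fold lower number from compound 2 to compound 3 (1.69 log units; beyond the scatter), with added uncertainty for the different aryl group. Compound 3 is therefore estimated at 200 nM, within 40 nM to 2000 nM.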

Compound 3, half-maximal inhibitory concentration: > 10000 nM
Compound 3: no number, only a limit; the forecaster's own chance of this, stated with the estimate: 10%; at least 50-fold (1.69 log units) between middle value and limit.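

An aryl group on the amide-type nitrogen is thus not enough by itself: in this assay compound 3 gives > 10000 nM, which is a limit and not a number. With the aryl ring kept, the group on it alone carries a large change, trifluoromethyl in place of acetoxy on an aromatic carbon giving an at least 84-fold higher number from compound 1 to compound 3 (1.92 log units; beyond the scatter). The step between the ethyl and 3-(trifluoromethyl)phenyl compounds cannot be read, because both values are limits: the limit of > 10000 nM in this assay, at which 2 of the 3 values shown sit.

Going by these compounds, how far compound 2 and compound 3 lie beyond that limit stays unknown, so neither can be ranked against the other. Among these compounds, also open is whether a hydroxyl or a methoxy group on the same aromatic carbon would give a number in this assay, or whether acetoxy is the only group there that does.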